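Sulfonyl aryl variation in a kallikrein-7 inhibitor series

This account rests on a few compounds, and the source may have more. Where it says the series, first, only, none or still open, it means among the compounds named here.

Measured so far:
compound 1 `CC1=NC(c2cn(S(=O)(=O)c3ccc(C)cc3)c3ccccc23)CN1`: 10000 nM
compound 2 `CC1=NC(c2cn(S(=O)(=O)c3cccc(Cl)c3)c3ccccc23)CN1`: > 30000 nM
compound 3 `CC1=NC(c2cn(S(=O)(=O)c3cccs3)c3ccc(C)cc23)CN1`: 11000 nM

In an assay on isolated protein for inhibition of kallikrein-7 (Homo sapiens), read by fluorescence, with stated times of 10 min and 30 min (a higher number here means a weaker inhibitor, a lower number a stronger inhibitor), compound 3 gives 11000 nM, the highest of the two plain numbers recorded. The nearest is compound 1 with 10000 nM; the two sit within the scatter of each other, so no order is claimed between them. Compound 2 returns only a limit, > 30000 nM, and no number (the limit of > 30000 nM in this assay, at which 1 of the 3 values shown sits).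

Compound 4 `CC1=NC(c2cn(S(=O)(=O)c3ccccc3F)c3ccc(C)cc23)CN1` differs from compound 3 in one place: 2-fluorophenyl in place of thiophen-2-yl on a sulfonyl sulfur.

Among the compounds with values here, only one measured step touches the same position, the aryl on the sulfonyl sulfur: an at least 3.0-fold higher number from compound 1 to compound 2 (0.47 log units; beyond the scatter). That change pushed the value onto the limit, so exchanging the aryl here can move this assay by at least a modest amount, and in the weaker direction. The exchange from thiophen-2-yl to 2-fluorophenyl is a different pair, so the direction is not fixed by it; a step of similar or smaller size, leaning weaker, is the working expectation.

The estimate for compound 4 is 14000 nM, within 5000 nM to 40000 nM, corresponding to an expected step of a 1.3-fold higher number from compound 3 to compound 4 (0.10 log units; within the scatter).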

Compound 4, half-maximal inhibitory concentration: 4100 nM
For compound 4 the middle estimate is 3.4-fold (0.53 log units) above the measured one; the whole stated range lies above it.
By their numbers in this assay, from the lowest: compound 4; then compounds 1 and 3 (each within the scatter of the next). At a limit, above all of these: compound 2.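

In this assay the aryl on the sulfonyl sulfur now shows a step towards a stronger inhibitor: a 2.7-fold lower number from compound 3 to compound 4 (0.43 log units; beyond the scatter). Within the data shown here, the only earlier step at this position, an at least 3.0-fold higher number from compound 1 to compound 2 (0.47 log units; beyond the scatter), ran the other way, so exchange at this place can move the number in either direction, though the two pairs do not share one core and no general order of aryl groups follows from them. Compound 2 remains a limit and not a number: the limit of > 30000 nM in this assay, at which 1 of the 4 values shown sits.

The compounds shown do not separate the fluorine of the 2-fluorophenyl from its six-membered aromatic ring, a separation that a plain phenyl on the core of compound 4 would give. As far as these compounds go, how an amine or a carboxylic acid on this aryl would read in this assay also stays open.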